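A bromo for a methoxy on compound 3

A few compounds are considered here, and "the series" means these few. Any claim that something is new, unique, unknown or untested is made for them only; others in the source may bear on it.

In an ADME assay on BJ cells (Homo sapiens) for cytotoxicity, read by luminescence, with a stated time of 72 h (a higher number here means that more compound is needed for the effect, a lower number that less compound is needed), compound 3 (`CCOC(=O)c1c(-c2cccc(OC)c2)[nH]c2cc(OC)c(Cl)cc2c1=O`) gives > 21500 nM, which is a limit and not a number. Among the compounds with values here, it has no measured neighbour with a readable number, since the series so far stands at the limit of > 21500 nM in this assay, at which 3 of the 3 values shown sit. Compound 1 (`CCOC(=O)c1c(-c2cccc(OC)c2)[nH]c2cc(OC)ccc2c1=O`) gives > 21500 nM, again a limit. Compound 2 (`CCOC(=O)c1c(-c2cccc(Br)c2)[nH]c2cc(OC)ccc2c1=O`) gives > 21500 nM, a limit as well.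

Compound 4 (`CCOC(=O)c1c(-c2cccc(Br)c2)[nH]c2cc(OC)c(Cl)cc2c1=O`) has not yet been measured. It differs from compound 3 by one exchange: bromo in place of methoxy on an aromatic carbon. In words, this is bromo in place of methoxy on an aromatic carbon, or 3-methoxyphenyl to 3-bromophenyl.

The same exchange has been made once on the core of compound 1, and the result is a step that the two limits leave unreadable from compound 1 to compound 2. The other measured change brings in a chloro, seen in a step that the two limits leave unreadable from compound 1 to compound 3. Neither step has a size that can be read, so both offer only the repeated limit as a guide.

No step beyond the usual scatter is therefore expected, and the estimate is a step that the limit leaves unreadable from compound 3 to compound 4. Compound 4 is expected at about 22000 nM, with an estimated range from 12000 nM to 40000 nM, and most likely it will again be reported only as a limit.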

Compound 4, half-maximal effective concentration: > 21500 nM
Compound 4 ended at the assay's limit; the forecaster's own chance of this, stated with the estimate: 85%; the middle value does not contradict the limit.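

In this assay compound 4 gives > 21500 nM, which is a limit and not a number. The steps to compound 4 from compound 3 and from compound 2 therefore cannot be read. The compounds shown leave open whether the bromo or the chloro exchange changes the half-maximal effective concentration at all, since the series stands at a single limit: the limit of > 21500 nM in this assay, at which 4 of the 4 values shown sit.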